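Working notes: aryl swap on the pyridine series, compound 4

This account rests on a few compounds, and the source may have more. Where it says the series, first, only, none or still open, it means among the compounds named here.

Measured so far:
compound 1 `Clc1ccc(-c2cc(-c3ccoc3)cc(-c3cccs3)n2)cc1` — 21100 nM
compound 2 `Clc1ccc(-c2cc(-c3ccc(Cl)o3)cc(-c3cccs3)n2)cc1` — 19200 nM
compound 3 `Cc1cccc(-c2cc(-c3ccc(Cl)o3)cc(-c3ccsc3)n2)c1` — 17900 nM

All three numbers come from a functional assay on DU-145 cells (Homo sapiens) for cytotoxicity, in the presence of a further agent that is not named here; a lower number here means a stronger inhibitor, a higher number a weaker inhibitor. Compound 3 sits at the lower edge of the set, but its values against compound 2 and compound 1 both lie within the usual scatter, so the three compounds cannot be told apart on these figures. For the measured compounds named here, the one single-point step measured so far, a 1.1-fold lower number from compound 1 to compound 2 (0.04 log units; within the scatter), also stays within the scatter.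

Compound 4 `Clc1ccc(-c2cc(-c3ccsc3)nc(-c3ccccc3Cl)c2)o1` is not yet measured. Relative to compound 3 the change is 2-chlorophenyl in place of 3-methylphenyl on an aromatic carbon. Going by the values given here, no measured step touches this aryl position; the only step recorded concerns the five-membered ring and gives no lead. On that basis compound 4 is expected to stay close to compound 3, with a step of a 1.0-fold higher number from compound 3 to compound 4 (0.00 log units; within the scatter) not distinguishable from the scatter.

The estimate for compound 4 in this assay is 18000 nM, with a range from 8000 nM to 40000 nM.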

Compound 4, half-maximal inhibitory concentration: 19300 nM
Compound 4: the middle estimate sits 1.1-fold (0.03 log units) below what was measured; low and high end bracket the measured number.
By their numbers in this assay, from the lowest: compounds 3, 2, 4 and 1 (each within the scatter of the next).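

In this assay, the aryl position next to the ring nitrogen now has a measured step of its own: a 1.1-fold higher number from compound 3 to compound 4 (0.03 log units; within the scatter). For the compounds shown here, the earlier step concerned only the five-membered ring, so this is the first reading at this position, and 2-chlorophenyl in place of 3-methylphenyl gives no change that can be told from the scatter. No supporting data bear on this result.

Going by these compounds alone, only this one exchange has been read here, both groups being six-membered aromatic rings of carbon only with no net charge, so whether the number responds to this position at all remains open. An aminomethyl group, a carboxylic acid or a longer alkyl chain in place of the aryl ring would test this, and the compounds shown give no indication of the outcome.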